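Methyl to phenyl on the nitrogen of compound 3

This account rests on a few compounds, and the source may have more. Where it says the series, first, only, none or still open, it means among the compounds named here.

In a functional assay on the whole organism with Mus musculus as the target (on this read-out lower numbers stand for an effect already at smaller amounts and higher numbers for an effect only at larger amounts of compound), compound 3 `CNc1c(C)c(C)c2c(c1C)CC(C)(C)O2` gives 16.6 mg/kg. Among the compounds with values here, compound 1 `CCCCCc1ccc(C2c3c(C)c(N)c(C)c(C)c3OC2(C)C)cc1` gives 42.2 mg/kg, so compound 3 holds the lower of the two true numbers measured so far. Compound 2 `Cc1c(C)c2c(c(C)c1NC=O)CC(C)(C)O2` is recorded at > 100 mg/kg, which is a limit of the assay and not a number.

The next compound to be tested is compound 4 `Cc1c(C)c2c(c(C)c1Nc1ccccc1)CC(C)(C)O2`. It has phenyl in place of methyl on a nitrogen on an aromatic ring, the change from methylamino to anilino: phenyl in place of methyl on a nitrogen on an aromatic ring.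

Within the data shown here, only one measured step touches this nitrogen. Methyl in place of formyl gave an at least 6.0-fold lower number from compound 2 to compound 3 (0.77 log units; beyond the scatter). As far as these compounds go, that step starts from the limit of > 100 mg/kg in this assay, at which 1 of the 3 values shown sits, so its full size remains unknown. Among the measured compounds shown here, it shows that the group on this nitrogen can matter, but it involves a different group, and no measured compound carries phenyl there. Its size therefore cannot simply be carried over, and no step beyond the scatter is expected in this assay. The direction leans slightly towards a higher number, since compound 3 at 16.6 mg/kg is already the lowest number here. The estimated step is a 1.8-fold higher number from compound 3 to compound 4 (0.26 log units; within the scatter). The expected value for compound 4 is 30 mg/kg, within an estimated range of 8 mg/kg to 100 mg/kg.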

Compound 4, dose for 50% inhibition: > 50 mg/kg
Compound 4: no number, only a limit; the forecaster's own chance of this, stated with the estimate: 25%; at least 1.6-fold (0.22 log units) between middle value and limit.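

In this assay compound 4 is recorded at > 50 mg/kg, which is a limit of the assay and not a number. Even so, a step can be read from it: phenyl in place of methyl on this nitrogen gives an at least 3.0-fold higher number from compound 3 to compound 4 (0.47 log units; beyond the scatter), so the earlier step on this nitrogen is no longer the only evidence that the group there matters, and here an aromatic ring of carbon only does not keep the effect at the dose level of the methyl compound. Methyl now stands apart among the three groups tried on this nitrogen, since replacing it with formyl or with phenyl each gives a step beyond the scatter towards a higher number, and the shared core stays the same in all three compounds.

As far as these compounds go, how high the true number of compound 4 lies stays open: the limit of > 50 mg/kg in this assay, at which 1 of the 4 values shown sits. The step from compound 2 to compound 4 cannot be read, with a limit on both sides, and it also remains open whether an ethyl group on this nitrogen would stay close to methyl or move towards phenyl.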